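Adding a Methoxy Group to Compound 2

The source may hold more compounds than are shown below. What is called first, only, known or untested is meant among the compounds shown, and "the series" means these compounds.

- Compound 1 `COc1cc(-c2nc(-c3ccccc3)c(-c3ccccc3)[nH]2)cc(OC)c1O` gives 264000 nM
- Compound 2 `COc1ccc(-c2nc(-c3ccccc3)c(-c3ccccc3)[nH]2)cc1OC` gives 94000 nM

In a functional assay on brain, read by spectrophotometry (a lower number here means a stronger inhibitor, a higher number a weaker inhibitor), compound 2 holds the lower number of the pair at 94000 nM, and its gap to compound 1 lies beyond the usual scatter. Compound 3 `COc1cc(-c2nc(-c3ccccc3)c(-c3ccccc3)[nH]2)cc(OC)c1OC` differs from compound 2 by one change, (methoxy in place of hydrogen on an aromatic carbon), with methoxy in place of hydrogen on an aromatic carbon. Among the measured compounds shown here, no measured pair shows this change alone, so the expectation is tentative. A modest rise in the number, meaning a weaker inhibitor, is expected, with an estimated 1.7-fold higher number from compound 2 to compound 3 (0.23 log units; within the scatter). For compound 3 the estimated value is 160000 nM, with an expected range from 70000 nM to 350000 nM.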

Compound 3, half-maximal inhibitory concentration: 61300 nM
The estimate for compound 3 lay 2.6-fold (0.42 log units) above the measured number; the whole stated range lies above it.
By their numbers in this assay, from the lowest: compounds 3 and 2 (each within the scatter of the next); then compound 1.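

In this assay, methoxy in place of hydrogen on this aromatic carbon, ortho to a methoxy group, gives a 1.5-fold lower number from compound 2 to compound 3 (0.19 log units; within the scatter), so the added group neither clearly helps nor clearly harms. The larger shift comes with methyl in place of hydrogen on the oxygen on the aromatic ring, a 4.3-fold lower number from compound 1 to compound 3 (0.63 log units; beyond the scatter), which lies beyond the scatter. No supporting data account for either step.

On these data alone, it remains open how an amine, a fluorine atom or a longer alkoxy chain at this position would compare with methoxy.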